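The compounds below may be only part of what the source reports. "The series", "measured", "known", "first", "only" and "open" are said of these compounds alone.

Compound 1, `COc1cc(C=C(C(=O)/C=C/c2cccc(OC)c2OC)C(=O)/C=C/c2cccc(OC)c2OC)cc(Br)c1O`, is measured in a functional assay on HepG2 cells (Homo sapiens) for antiproliferative activity, read by sulforhodamine B assay, with a stated time of 48 h (on this read-out higher numbers stand for weaker inhibition and lower numbers for stronger inhibition), where compound 1 gives 240 nM. Compound 2, `COc1cc(C=C(C(=O)/C=C/c2cccc(OC)c2OC)C(=O)/C=C/c2cccc(OC)c2OC)cc(OC)c1O`, differs from compound 1 by one change, (methoxy in place of bromo on an aromatic carbon), and in this assay compound 2 gives 210 nM. This change gave a 1.1-fold lower number from compound 1 to compound 2 (0.06 log units; within the scatter).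

Compound 3, `COc1ccc(/C=C/C(=O)C(=Cc2cc(Br)c(O)c(OC)c2)C(=O)/C=C/c2ccc(OC)cc2OC)c(OC)c1`, is built from the same atoms as compound 1, joined differently; the difference between the two cores is not broken down here. In this assay compound 3 gives 1190 nM, the highest of the three measured numbers, and its distance from compound 1 and from compound 2 lies beyond the scatter.

Compound 4, `COc1ccc(/C=C/C(=O)C(=Cc2cc(OC)c(O)c(OC)c2)C(=O)/C=C/c2ccc(OC)cc2OC)c(OC)c1`, stands to compound 3 as compound 2 stands to compound 1: it carries the same change, (methoxy in place of bromo on an aromatic carbon), set on the same kind of ring position. Since the change in this setting is the same one, compound 4 is expected to sit close to compound 3. The estimate rests on a step of a 1.1-fold lower number from compound 3 to compound 4 (0.03 log units; within the scatter), expected because a 1.1-fold lower number from compound 1 to compound 2 (0.06 log units; within the scatter) stayed within the scatter. Compound 4 is therefore estimated at 1100 nM, with a likely range from 550 nM to 2400 nM.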

Compound 4, half-maximal inhibitory concentration: 320 nM
Estimate against measurement, compound 4: 3.4-fold (0.54 log units) above; measured number outside the range, below it.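

In this assay, methoxy in place of bromo gives a 3.7-fold lower number from compound 3 to compound 4 (0.57 log units; beyond the scatter) on the core of compound 3, while the same change gives a 1.1-fold lower number from compound 1 to compound 2 (0.06 log units; within the scatter) on the core of compound 1. The size of this change therefore did not carry from one core to the other, and the two steps differ by more than the scatter: the same change on two cores in this assay, a 1.1-fold lower number (0.06 log units; within the scatter) from compound 1 to compound 2 and a 3.7-fold lower number (0.57 log units; beyond the scatter) from compound 3 to compound 4, 3.3-fold (0.51 log units) apart, beyond the scatter of two such steps. This rests on a single pair for each core, so it shows that the outcome depends on the core here, but not which feature of the core is responsible or how the change would behave on any further core.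

The compounds shown leave open how other groups at this place on the ring, such as chloro, an amine or a carboxylic acid, would behave on the two cores. They also leave open which part of the difference between the two cores separates the two steps.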